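Benzyl substituent swap in a weakly active series

This account rests on a few compounds, and the source may have more. Where it says the series, first, only, none or still open, it means among the compounds named here.

Measured compounds:
compound 1 `CCOC(=O)C(=O)CC(=O)/C=C/c1cn(CCC(C)C)c2ccccc12` — > 40 uM
compound 2 `CCOC(=O)C(=O)CC(=O)/C=C/c1cn(Cc2ccc(Cl)cc2)c2ccccc12` — 40 uM

Working notes. Within the data shown here, in an assay on isolated protein for inhibition of DNA nucleotidylexotransferase (Homo sapiens), read by scintillation counting, with a stated time of 10 min (on this read-out lower numbers stand for stronger inhibition and higher numbers for weaker inhibition), compound 2 gives 40 uM, the only number in the set. The result for compound 1 in this assay is a limit, > 40 uM. The step of a number no higher from compound 1 to compound 2 (the limit leaves the size open) cannot be sized because the limit of > 40 uM in this assay, at which 1 of the 2 values shown sits, leaves one end of it open; only its direction is fixed.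

Compound 3 `CCOC(=O)C(=O)CC(=O)/C=C/c1cn(Cc2ccc(C#N)cc2)c2ccccc12` differs from compound 2 by cyano in place of chloro on an aromatic carbon. Among the measured compounds shown here, no measured step touches this change, and the single measured step concerns a different group with an unreadable size, so it offers no guide to magnitude. The expectation therefore rests on compound 2 alone: compound 3 is expected to sit close to it, with an estimated step of no change at the digits printed from compound 2 to compound 3 (within the scatter) within the scatter. Compound 3 is estimated at 40 uM, within 15 uM to 120 uM, with a real chance that this assay reports only a limit.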

Compound 3, concentration for 50% inhibition: > 40 uM
Compound 3: a limit, no number; the forecaster's own chance of this, stated with the estimate: 50%; the middle value lies on the limit itself.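

In this assay, cyano in place of chloro on an aromatic carbon, para to a large group, gives a number no lower from compound 2 to compound 3 (the limit leaves the size open), so this swap does not bring the number lower than that of compound 2. Among these compounds, compound 3 gives > 40 uM, which is a limit, and compound 2 remains the only compound with a number. The size of neither new step can be read because each ends on a limit: the limit of > 40 uM in this assay, at which 2 of the 3 values shown sit.

As far as these compounds go, how far compound 3 lies from compound 2 remains open, as does whether an amine, a carboxylic acid or a methoxy group at this ring carbon would give a clearly lower number. Also open, from the compounds shown here alone, is how a longer chain in place of the 4-chlorobenzyl group of compound 2 would read in this assay.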